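This account rests on a few compounds, and the source may have more. Where it says the series, first, only, none or still open, it means among the compounds named here.

Compound 1 `CCOC(=O)c1nn(-c2ccc(C(C)(C)C)cc2)c(=O)c2c(N)scc12` gives 9750 nM in an assay on CHO-K1 cells with adenosine receptor A1 (Homo sapiens) as the target; a lower number here means that less compound is needed, a higher number that more compound is needed for the effect.
Compound 2 `CCOC(=O)c1nn(-c2cccc(Cl)c2)c(=O)c2c(N)scc12` gives 5700 nM in this assay.
Compound 3 `CCOC(=O)c1nn(-c2ccc(O)cc2)c(=O)c2c(N)scc12` gives 7100 nM in this assay.

All three share one core and differ only in the aromatic ring on its nitrogen. Compound 3 does not stand apart from the others: a 1.2-fold higher number from compound 2 to compound 3 (0.10 log units; within the scatter), and a 1.4-fold lower number from compound 1 to compound 3 (0.14 log units; within the scatter). Compound 4 `CCOC(=O)c1nn(-c2ccc(C(F)(F)F)cc2)c(=O)c2c(N)scc12` arises from compound 3 by trifluoromethyl in place of hydroxy on an aromatic carbon. The swap of a tert-butyl for a hydroxy group on this ring stayed within the scatter, and so did the exchange of one substituted ring for another. With both earlier changes at this part of the molecule leaving this assay essentially unchanged, no step beyond the scatter is expected here, a 1.1-fold higher number from compound 3 to compound 4 (0.05 log units; within the scatter). Compound 4 is therefore estimated at 8000 nM, within a range from 4000 nM to 16000 nM.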

Compound 4, half-maximal effective concentration: 8400 nM
The estimate for compound 4 lay 1.1-fold (0.02 log units) below the measured number, within the range that was stated.
By their numbers in this assay, from the lowest: compounds 2, 3, 4 and 1 (each within the scatter of the next).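

Trifluoromethyl, with no hydrogen-bond donor or acceptor, replaces hydroxy on this aromatic carbon in this assay and the number stays within the scatter (a 1.2-fold higher number from compound 3 to compound 4 (0.07 log units; within the scatter)). Replacing tert-butyl with it does the same (a 1.2-fold lower number from compound 1 to compound 4 (0.06 log units; within the scatter)), so among these compounds the hydrogen-bond donor and acceptor of hydroxy are not needed to keep the number in this range. No measurement shown offers a reason for this. From the compounds shown here alone, what an amine or a carboxylic acid on this ring would do remains open, as does whether any group here could move the number beyond the scatter.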